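From Bromo to Trifluoromethyl: Estimating Compound 4

A few compounds are considered here, and "the series" means these few. Any claim that something is new, unique, unknown or untested is made for them only; others in the source may bear on it.

Three compounds share one core and differ only in the group attached to the carbonyl carbon. Compound 1 `O=C(/C=C/c1ccc2c(c1)B(O)OC2)c1ccco1` carries furan-2-yl; in a functional assay on SK-OV-3 cells (Homo sapiens) for cytotoxicity, read by MTT assay, with a stated time of 48 h (a higher number here means a weaker inhibitor, a lower number a stronger inhibitor), compound 1 gives 20700 nM. Compound 2 `O=C(/C=C/c1ccc2c(c1)B(O)OC2)c1cccnc1` carries pyridin-3-yl, and compound 2 gives 18500 nM, a step of a 1.1-fold lower number from compound 1 to compound 2 (0.05 log units; within the scatter). Compound 3 `O=C(/C=C/c1ccc2c(c1)B(O)OC2)c1ccc(Br)cc1` carries 4-bromophenyl and gives 4500 nM, the lowest of the three numbers and so the strongest inhibitor here, with steps of a 4.6-fold lower number from compound 1 to compound 3 (0.66 log units; beyond the scatter) and a 4.1-fold lower number from compound 2 to compound 3 (0.61 log units; beyond the scatter).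

Compound 4 `O=C(/C=C/c1ccc2c(c1)B(O)OC2)c1ccc(C(F)(F)F)cc1` keeps that ring but changes its substituent: trifluoromethyl in place of bromo on an aromatic carbon. Within the data shown here, no measured step swaps one group for another on this ring; every step so far replaced the whole ring at the carbonyl carbon, so the bearing of those steps is indirect. The change is therefore expected to move the number little, and the step from compound 3 to compound 4 is estimated at no change at the digits printed from compound 3 to compound 4 (within the scatter). Compound 4 is expected to give 4500 nM in this assay, within a range of 1500 nM to 13500 nM.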

Compound 4, half-maximal inhibitory concentration: 3700 nM
For compound 4 the middle estimate is 1.2-fold (0.09 log units) above the measured one; the range from low to high includes it.
By their numbers in this assay, from the lowest: compounds 4 and 3 (each within the scatter of the next); then compounds 2 and 1 (each within the scatter of the next).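

Among these compounds, changing only the substituent, rather than replacing the whole ring at the carbonyl carbon, gives the first direct reading of this position in this assay and shows a 1.2-fold lower number from compound 3 to compound 4 (0.09 log units; within the scatter) after a single bromine gives way to the four heavy atoms of trifluoromethyl. The low number reached with compound 3 therefore does not depend on bromine being present, since compound 4 contains none and gives 3700 nM in the same assay. No measurement of any property of these groups is available to explain why the two read alike.

From the compounds shown here alone, whether an amine, a carboxylic acid or a longer chain such as butyl at this same place would keep the number this low remains open. The compounds shown also leave open what the phenyl ring does with no substituent at all, carrying only hydrogen there.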